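A few compounds are considered here, and "the series" means these few. Any claim that something is new, unique, unknown or untested is made for them only; others in the source may bear on it.

Compound 1 `CCC(C)Sc1nc(N)nc2c1ncn2[C@@H]1O[C@H](CO)[C@@H](O)[C@H]1O`: 63100 nM
Compound 2 `Nc1nc(SCc2ccc(F)cc2)c2ncn([C@@H]3O[C@H](CO)[C@@H](O)[C@H]3O)c2n1`: 1150 nM
Compound 3 `CSc1nc(N)nc2c1ncn2[C@@H]1O[C@H](CO)[C@@H](O)[C@H]1O`: 204000 nM

In an assay on isolated protein for binding affinity to Equilibrative nucleoside transporter 1 (Homo sapiens) (on this read-out higher numbers stand for weaker inhibition and lower numbers for stronger inhibition), compound 3 gives the highest of the three numbers, with compound 1 nearest to it and compound 2 furthest away. Compound 4 `Nc1nc(SCCc2ccccc2)c2ncn([C@@H]3O[C@H](CO)[C@@H](O)[C@H]3O)c2n1` differs from compound 3 by benzyl in place of hydrogen on a saturated chain carbon bound to a sulfur. Going by the values given here, two measured steps bear on this change. The step of a 180-fold higher number from compound 2 to compound 3 (2.25 log units; beyond the scatter) removed an aromatic ring from that same saturated chain carbon, and the step of a 3.2-fold higher number from compound 1 to compound 3 (0.51 log units; beyond the scatter) shortened the group on the sulfur. Putting an aromatic ring back onto that carbon should therefore bring a large step in the lowering direction. Compound 4 is thus expected to land near compound 2 rather than compound 3. The estimate for compound 4 is 3000 nM, between 500 nM and 20000 nM, an expected step of a 68-fold lower number from compound 3 to compound 4 (1.83 log units; beyond the scatter).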

Compound 4, half-maximal inhibitory concentration: 16200 nM
Compound 4: middle estimate off by 5.4-fold (0.73 log units), on the low side; the measured number falls inside the stated range.
By their numbers in this assay, from the lowest: compound 2; then compound 4; then compound 1; then compound 3.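

In this assay, phenethyl on the sulfur clearly improves on methyl (a 13-fold lower number from compound 3 to compound 4 (1.10 log units; beyond the scatter)), but it falls well short of 4-fluorobenzyl (a 14-fold higher number from compound 2 to compound 4 (1.15 log units; beyond the scatter)), so an aromatic ring alone does not settle the result and its placement or substitution matters. Phenethyl is also only modestly better than the non-aromatic sec-butyl (a 3.9-fold lower number from compound 1 to compound 4 (0.59 log units; beyond the scatter)). No measurement here explains these gaps.

Compound 2 and compound 4 differ in both chain length and fluorine, so the effects of these two features cannot be separated. Plain benzyl on the sulfur would separate them, while 3-phenylpropyl would extend the chain series.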